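Mirror-image switch at one carbon, effect expected unchanged

A few compounds are considered here, and "the series" means these few. Any claim that something is new, unique, unknown or untested is made for them only; others in the source may bear on it.

Of the compounds shown here, two have been measured so far in an ADME assay on the whole organism with Oryza sativa as the target, tested at 10 uM; on this read-out higher numbers stand for a weaker effect at the one concentration tested and lower numbers for a stronger effect. Compound 1, `CCCCCCCc1ccc(NC(=O)N[C@@H](C)c2ccccc2)cc1`, carries a long straight chain on its aromatic ring; in this assay compound 1 gives 99%. Compound 2, `CCOC(=O)c1ccc(NC(=O)N[C@H](C)c2ccccc2)cc1`, carries an ester on that ring instead; in this assay compound 2 gives 92%. The two readings sit close together, both near the top of the scale, which here means a weak effect at the single concentration tested. The reading of compound 2 is the smaller of the two, but the gap to compound 1 stays inside the usual scatter, so neither compound can be called stronger or weaker than the other on this evidence.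

Compound 3, `CCOC(=O)c1ccc(NC(=O)N[C@@H](C)c2ccccc2)cc1`, is the next compound in line. Its relation to compound 2: the two compounds have the same atoms and bonds and differ only in configuration as drawn: 1 of 1 stereo elements differ; a stereocentre at a saturated chain carbon is drawn R in compound 2 and S in compound 3. Among the measured compounds shown here, no step between two measured compounds tells how this assay responds to such a switch. Since compound 1 and compound 2 lie so close, and since compound 3 keeps every atom and bond of compound 2, the expected step of a number 3 percentage points higher from compound 2 to compound 3 (within the scatter) is none beyond the scatter. Compound 3 is therefore estimated to give 95% in this assay, with a likely range from 85% to 100%.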

Compound 3, a percentage reported as activity, at one concentration (the size of the read-out at that concentration, not a potency): 92%
For compound 3 the middle estimate is 3 percentage points above the measured one; the range from low to high includes it.
By their numbers in this assay, from the lowest: compounds 2, 3 and 1 (each within the scatter of the next).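

In this assay, among the compounds shown here, moving the stereocentre at the saturated chain carbon from R to S gives no change at the digits printed from compound 2 to compound 3 (within the scatter), which is the first direct test of this centre. At this single concentration, the read-out does not separate these two mirror-image forms, and the comparison is a clean one for a simple structural reason: the fact that compounds 2 and 3 differ only in the configuration as drawn. The new compound also provides a one-place comparison on the aromatic carbon, where ethoxycarbonyl in place of heptyl gives a number 7 percentage points lower from compound 1 to compound 3 (within the scatter), so this exchange shows no step beyond the scatter either.

From the compounds shown here alone, all three readings sit near the top of the scale, where the effect is weak, so it remains open whether configuration would matter in a compound with a stronger effect at this centre. Also open, going by these compounds, is how an amine or a carboxylic acid on that aromatic carbon would read, and whether the heptyl compound would keep its reading with the stereocentre drawn the other way.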